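A few compounds are considered here, and "the series" means these few. Any claim that something is new, unique, unknown or untested is made for them only; others in the source may bear on it.

Working notes on the series in a functional assay on HeLa cells (Homo sapiens) for inhibition, read by MTT assay, with a stated time of 72 h; a higher number here means a weaker inhibitor, a lower number a stronger inhibitor. Compound 3 `Nc1ncnc2c1c(-c1cnc3[nH]ccc3c1)nn2CCCCCCC(=O)NO` gives 22000 nM in this assay, the highest of the two numbers recorded. Compound 1 `CNC(=O)CCCCCCCn1nc(-c2ccc3oc(N)nc3c2)c2c(N)ncnc21` is the nearest, with 12900 nM in this assay; the gap between compound 1 and compound 3 lies within the scatter, so no order is read from it. Compound 2 `Nc1nc2cc(-c3nn(CCCCCCCCCC(=O)NO)c4ncnc(N)c34)ccc2o1` returns only a limit in this assay, > 50000 nM, and not a number.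

Compound 4 `Nc1ncnc2c1c(-c1cnc3[nH]ccc3c1)nn2CCCCCCCCC(=O)NO` has not yet been measured. Its difference from compound 3 is 2-(hydroxycarbamoyl)ethyl in place of hydroxycarbamoyl on a saturated chain carbon, six bonds along the chain from an aromatic nitrogen. Among the measured compounds shown here, one measured step bears on it, and only in part: an at least 3.8-fold higher number from compound 1 to compound 2 (0.58 log units; beyond the scatter). That step also extended the chain, but at the same time replaced methylcarbamoyl with the hydroxycarbamoyl end, so it does not isolate the chain extension. The longer hydroxycarbamoyl compound 2 sits at the limit of > 50000 nM in this assay, at which 1 of the 3 values shown sits.

Taken together, the expected step is a 1.6-fold higher number from compound 3 to compound 4 (0.20 log units; within the scatter), toward a higher number, with a real chance that only a limit is reported. Compound 4 is estimated at 35000 nM in this assay, within a range of 15000 nM to 80000 nM.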

Compound 4, half-maximal inhibitory concentration: 7470 nM
Estimate against measurement, compound 4: 4.7-fold (0.67 log units) above; measured number outside the range, below it.
By their numbers in this assay, from the lowest: compounds 4, 1 and 3 (each within the scatter of the next, the first and the last beyond it). At a limit, above all of these: compound 2.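

In this assay, the extension of the chain on the shared core of compound 3 gives a 2.9-fold lower number from compound 3 to compound 4 (0.47 log units; beyond the scatter), so the two added carbons alone move the number down at this position. The earlier step, an at least 3.8-fold higher number from compound 1 to compound 2 (0.58 log units; beyond the scatter), changed the chain and its end group together, whereas this pair keeps the core and the hydroxycarbamoyl end fixed and changes only hydroxycarbamoyl to 2-(hydroxycarbamoyl)ethyl, on a saturated chain carbon, six bonds along the chain from an aromatic nitrogen. The fall holds for this one pair only, and compound 2, which carries a longer chain on a different core, gives a limit and not a number: the limit of > 50000 nM in this assay, at which 1 of the 4 values shown sits.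

On these data alone, whether the number keeps falling with a longer chain on the core of compound 3, or turns upward at some chain length, remains open. Also open, as far as these compounds go, is how far the result depends on the hydroxycarbamoyl end, since neither a carboxylic acid nor a primary amide at the end of this chain appears on the core of compound 3.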